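Benzyl purines in NCI-H460 cell cytotoxicity: a meta analogue

A few compounds are considered here, and "the series" means these few. Any claim that something is new, unique, unknown or untested is made for them only; others in the source may bear on it.

Of the compounds shown here, two have numbers so far. Compound 1 `ClCc1cccc(Cn2cnc3ncnc(Cl)c32)c1` gives 91200 nM in a functional assay on NCI-H460 cells (Homo sapiens) for cytotoxicity, read by sulforhodamine B assay, with a stated time of 48 h; a higher number here means that more compound is tolerated, a lower number that less compound is tolerated. Compound 2 `ClCc1ccc(Cn2cnc3nc(Cl)nc(Cl)c32)cc1` gives 79400 nM in this assay; its number and that of compound 1 differ by less than the scatter, so the two sit at the same level on what is shown. Going by the values given here, no step between two measured compounds that differ in one place is available, so nothing computed links the two.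

Compound 3 `ClCc1cccc(Cn2cnc3nc(Cl)nc(Cl)c32)c1` has not yet been run in this assay. It differs from compound 1 by chloro in place of hydrogen on an aromatic carbon of the core of compound 1, between two ring nitrogen atoms. Compound 2 carries the same chloro pattern on the core with a different arrangement of the benzyl part, and compound 2 with 79400 nM sits within the scatter of compound 1 with 91200 nM.

On that basis the step from compound 1 to compound 3 is expected to be a 1.1-fold lower number from compound 1 to compound 3 (0.06 log units; within the scatter), that is, none beyond the scatter in either direction. Compound 3 is estimated at 80000 nM in this assay, with a range from 40000 nM to 160000 nM.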

Compound 3, concentration lethal to 50% of the cells: 5490 nM
Estimate against measurement, compound 3: 15-fold (1.16 log units) above, outside the stated range (below it).
By their numbers in this assay, from the lowest: compound 3; then compounds 2 and 1 (each within the scatter of the next).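

In this assay, chloro in place of hydrogen on an aromatic carbon, between two ring nitrogen atoms, gives a 17-fold lower number from compound 1 to compound 3 (1.22 log units; beyond the scatter) and so shows that this position of the core is far from indifferent to the change, which the earlier pair of compounds could not show. Compound 2 carries the same chloro on the core and gives 79400 nM in this read-out, while compound 3 gives 5490 nM with its different arrangement of the benzyl part, so the chloro does not bring the low number on its own; among the compounds shown, that number appears only where this chloro and the benzyl arrangement of compound 3 occur together. Nothing available speaks to the reason for the large step at this position.

From the compounds shown here alone, it remains open whether a fluoro, a methoxy or an amine on the same aromatic carbon would follow the chloro, or whether the step depends on chlorine specifically. Going by these compounds, it also remains open whether the same step would appear with the benzyl arrangement of compound 2 or with a longer chain in place of the benzyl part.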